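The compounds below may be only part of what the source reports. "The series", "measured", "known", "first", "only" and "open" are said of these compounds alone.

Working notes on the series. Three compounds have been run in a functional assay on MDA-MB-231 cells (Homo sapiens) for cytotoxicity, read by MTT assay, with a stated time of 72 h; on this read-out lower numbers stand for stronger inhibition and higher numbers for weaker inhibition. Compound 1 `Cc1ccc(-c2ccc(C)n2-c2ccc(-c3nc4ccccc4s3)cc2)cc1` gives 17800 nM. Compound 2 `COc1cc(-c2ccc(C)n2-c2ccc(-c3nc4ccccc4s3)cc2)cc(OC)c1OC` gives 16000 nM. Compound 3 `Cc1ccc(-c2ccc(F)cc2)n1-c1ccc(-c2nc3ccc(F)cc3s2)cc1` gives 14100 nM. Compound 2 stands at the second highest of the three numbers, and both neighbours lie within the usual scatter of it: compound 1 with a slightly higher number and compound 3 with a slightly lower one, so no ordering among the three can be claimed from these values.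

Compound 4 `COc1cc(-c2ccc(C)n2-c2ccc(-c3nc4ccc(F)cc4s3)cc2)cc(OC)c1OC` has not yet been measured. It differs from compound 2 in one place: fluoro in place of hydrogen on an aromatic carbon. Fluoro in place of hydrogen on an aromatic carbon is the whole change. Among the compounds with values here, no pair of measured compounds differs in this one place alone, so no measured step reads across directly. Compound 3 carries the same fluorinated fused ring together with a second fluoro elsewhere, and its value of 14100 nM sits within the scatter of compound 2, which gives no sign of a large effect from fluorination here.

The step from compound 2 to compound 4 in this assay is expected to be a 1.1-fold lower number from compound 2 to compound 4 (0.06 log units; within the scatter), in effect no change beyond the scatter. Compound 4 is estimated at 14000 nM, with a range from 7000 nM to 28000 nM.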

Compound 4, half-maximal inhibitory concentration: 15400 nM
Compound 4: middle estimate off by 1.1-fold (0.04 log units), on the low side; the measured number falls inside the stated range.
By their numbers in this assay, from the lowest: compounds 3, 4, 2 and 1 (each within the scatter of the next).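

In this assay, within the data shown here, the change from 1,3-benzothiazol-2-yl to 6-fluoro-1,3-benzothiazol-2-yl now has a direct reading, a 1.0-fold lower number from compound 2 to compound 4 (0.02 log units; within the scatter), where the earlier compounds offered no pair differing in this one place alone. Among these compounds, on the background of compound 2, then, introducing the fluoro on the fused system of two rings leaves the number within the usual scatter, so this single heavy atom at this position gives no measurable step in this read-out. No measured property of these compounds bears on this result, and the data offer no account of it.

Among the compounds shown here, this is a single pair, and it remains open whether the same change would read alike on the core of compound 1, or on that of compound 3, which has no partner lacking its fluoro groups and so gives no step of its own. It also remains open whether this position tolerates any substituent in the same way, since what an amine or a carboxylic acid in place of the fluoro would do to the number cannot be told from the compounds shown.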